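The compounds below may be only part of what the source reports. "The series", "measured", "known", "first", "only" and "open" are said of these compounds alone.

Compound 1 `COc1cc[nH]c1/C=C1\C(=O)Nc2ccc(F)c(C#C[C@H](N)CO)c21` and compound 2 `COc1cc[nH]c1/C=C1\C(=O)Nc2ccc(F)c(C#C[C@@H](N)CO)c21` carry a 1-amino-2-hydroxyethyl group on a triple-bonded carbon and differ only in the configuration drawn at the saturated chain carbon (the fact that compounds 1 and 2 differ only in the configuration as drawn). In a functional assay on SW480 cells (Homo sapiens) for inhibition (on this read-out lower numbers stand for stronger inhibition and higher numbers for weaker inhibition), compound 1 gives 270 nM and compound 2 gives 205 nM, so that a 1.3-fold lower number from compound 1 to compound 2 (0.12 log units; within the scatter). Compound 3 `CN[C@H](C#Cc1c(F)ccc2c1/C(=C/c1[nH]ccc1OC)C(=O)N2)[C@@H](C)O` carries 2-hydroxy-1-(methylamino)propyl at the same place, and in this assay compound 3 gives 140 nM, the lowest of the three numbers shown, though a 1.9-fold lower number from compound 1 to compound 3 (0.29 log units; within the scatter) and a 1.5-fold lower number from compound 2 to compound 3 (0.17 log units; within the scatter) both stay within the scatter.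

Compound 4 `COc1cc[nH]c1/C=C1\C(=O)Nc2ccc(F)c(C#C[C@@H]3C[C@@H](O)CN3)c21` has not yet been measured. The change from compound 3 is this: 4-hydroxypyrrolidin-2-yl in place of 2-hydroxy-1-(methylamino)propyl on a triple-bonded carbon. For the measured compounds named here, every measured step so far concerns that same substituent on the triple-bonded carbon, and none of them moved the number beyond the scatter. The step to compound 4 again keeps the count of heavy atoms, donors and acceptors while closing the chain into the five-membered ring. On that basis no step beyond the scatter is expected, in either direction: a 1.1-fold higher number from compound 3 to compound 4 (0.03 log units; within the scatter). For compound 4 in this assay the estimate is 150 nM, with a range expected from 60 nM to 400 nM.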

Compound 4, half-maximal inhibitory concentration: 44 nM
Beside the measured number, compound 4's estimate is 3.4-fold (0.53 log units) above it, and the stated range ends above it.
By their numbers in this assay, from the lowest: compound 4; then compounds 3, 2 and 1 (each within the scatter of the next).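

Closing the open chain into 4-hydroxypyrrolidin-2-yl on the triple-bonded carbon gives the first step at this position that lies beyond the scatter: in this assay there is a 3.2-fold lower number from compound 3 to compound 4 (0.50 log units; beyond the scatter), although the count of heavy atoms, donors and acceptors stays the same, so those counts alone do not set the number here. The result also holds against the two compounds with 1-amino-2-hydroxyethyl, with a 4.7-fold lower number from compound 2 to compound 4 (0.67 log units; beyond the scatter) and a 6.1-fold lower number from compound 1 to compound 4 (0.79 log units; beyond the scatter), which sets compound 4 apart from all three open-chain compounds, themselves within the scatter of one another. Nothing available explains why the ring form gives the lower number.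

On these data alone, with a single ring compound and a single drawn configuration, it remains open whether the other stereoisomers of 4-hydroxypyrrolidin-2-yl would give a similar number. As far as these compounds go, it is equally open whether the hydroxyl is needed, as a plain pyrrolidin-2-yl group would show, and whether a six-membered piperidine ring or a methyl on the ring nitrogen would keep the gain.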